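The compounds below may be only part of what the source reports. "The series", "measured", "known", "first", "only" and "open" are said of these compounds alone.

Measured compounds in an assay on HEK293 cells for displacement of a labelled ligand from Melanocortin receptor 4 (Homo sapiens); on this read-out higher numbers stand for weaker inhibition and lower numbers for stronger inhibition:
- compound 1, `CC(C)[C@H](NC(=O)CCN(C)C)c1cccc(F)c1N1CCN(C(=O)[C@@H]2CN(C(C)C)C[C@H]2c2ccc(F)c(Cl)c2)CC1`, gives 260 nM
- compound 2, `CC(C)[C@H](NC(=O)CCN(C)C)c1cccc(F)c1N1CCN(C(=O)[C@@H]2CN(C(C)C)C[C@H]2c2ccc(C(F)(F)F)cc2F)CC1`, gives 61 nM

Among the measured compounds shown here, compound 2 has the lowest number of the two in this assay; its nearest neighbour is compound 1, and the single step recorded is a 4.3-fold lower number from compound 1 to compound 2 (0.63 log units; beyond the scatter). That step changes only the aryl group on the saturated ring carbon and shows that this position responds to substitution on the pending phenyl.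

Compound 3, `CC(C)[C@H](NC(=O)CCN(C)C)c1cccc(F)c1N1CCN(C(=O)[C@@H]2CN(C(C)C)C[C@H]2c2cc(F)cc(F)c2)CC1`, is not yet measured. It differs from compound 2 in one place: 3,5-difluorophenyl in place of 2-fluoro-4-(trifluoromethyl)phenyl on a saturated ring carbon. The step from compound 1 to compound 2 is the only one that bears on this change, since it exchanges aryl groups at the same place, but neither of the measured aryl groups is the 3,5-difluorophenyl entering here. A shift of the size seen from compound 1 to compound 2 is plausible; its direction is uncertain, and the loss of the trifluoromethyl group on the aryl leaves the change closer in kind to compound 1 than to compound 2. A modest move toward a higher number in this assay is therefore expected, of about a 3.3-fold higher number from compound 2 to compound 3 (0.52 log units; beyond the scatter). Compound 3 is estimated at 200 nM, with a range from 60 nM to 650 nM.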

Compound 3, inhibition constant: 7800 nM
Compound 3: the middle estimate sits 39-fold (1.59 log units) below what was measured, and the stated range ends below it.
By their numbers in this assay, from the lowest: compound 2; then compound 1; then compound 3.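

In this assay the aryl group on the saturated ring carbon governs the read-out far more strongly than the first pair indicated, with 3,5-difluorophenyl bringing a 130-fold higher number from compound 2 to compound 3 (2.11 log units; beyond the scatter) against only a 4.3-fold lower number from compound 1 to compound 2 (0.63 log units; beyond the scatter) between the two earlier aryl groups. The loss is not tied to the removal of trifluoromethyl alone: compound 1 also carries no trifluoromethyl group, yet 3,5-difluorophenyl still brings a 30-fold higher number from compound 1 to compound 3 (1.48 log units; beyond the scatter) when it replaces 3-chloro-4-fluorophenyl. Nothing on hand gives a reason for this large shift.

The three aryl groups differ in several substituents at once, so the contribution of any single substituent stays unresolved, and a plain phenyl, a 4-fluorophenyl or a 3,5-dichlorophenyl on this carbon would give more direct comparisons. From the compounds shown here alone, it also remains open whether the same order of aryl groups holds when a cyclopropyl or tert-butyl group takes the place of the isopropyl group on the five-membered ring, or when the dimethylamino chain of the shared core is changed.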